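This account rests on a few compounds, and the source may have more. Where it says the series, first, only, none or still open, it means among the compounds named here.

Measured in a functional assay on A2780 cells (Homo sapiens) for antiproliferative activity; a higher number here means a weaker inhibitor, a lower number a stronger inhibitor:
- compound 1 `Cc1ccc2c(c1C)CN(C(=O)N(C)C)CC2c1cccc(Cl)c1` gives 3020 nM
- compound 2 `CN(C)C(=O)N1Cc2cc(F)ccc2C(c2cccc(O)c2)C1` gives "not determined" (no result reported)
- compound 3 `CN(C)C(=O)N1Cc2cc(Cl)ccc2C(c2cccc(O)c2)C1` gives 1190 nM

Compound 3 stands at the low end of the two numbers available in this assay, making it the stronger inhibitor of the pair. Compound 1 has the nearest number, and the gap between the two lies beyond the usual scatter. Compound 2 adds no number to the comparison.

The next compound to be read is compound 4 `COc1ccc2c(c1)CN(C(=O)N(C)C)CC2c1cccc(O)c1`, which has methoxy in place of chloro on an aromatic carbon, meta to a fused ring and para to a fused ring methoxy in place of chloro on an aromatic carbon and is otherwise the same as compound 3.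

For the measured compounds named here, no pair of measured compounds differs in one place only, so this exchange has no direct precedent. Going by the values given here, with compound 3 at 1190 nM as the lowest number so far, a modest loss seems the more likely outcome, though a result within the scatter would not surprise. The estimated move is a 2.1-fold higher number from compound 3 to compound 4 (0.32 log units; beyond the scatter), in the direction of a higher number in this assay and thus a somewhat weaker inhibitor.

For compound 4 the expected value is 2500 nM, with an estimated range from 700 nM to 9000 nM, kept wide given how few numbers support it.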

Compound 4, half-maximal inhibitory concentration: 402 nM
Compound 4: middle estimate off by 6.2-fold (0.79 log units), on the high side; measured number below the stated range.
By their numbers in this assay, from the lowest: compound 4; then compound 3; then compound 1.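

In this assay, for the compounds shown here, the exchange of chloro for methoxy on this aromatic carbon of the fused two-ring system gives a 3.0-fold lower number from compound 3 to compound 4 (0.47 log units; beyond the scatter) and provides the first single-place step, showing that the number responds to the group at this position by more than the scatter. The incoming methoxy, with 2 heavy atoms and 1 hydrogen-bond acceptor, replaces chloro, with 1 heavy atom and no hydrogen-bond acceptor, and the number falls rather than rises, so this position accepts the exchange without a loss in this assay. No measurement at hand bears on the reason for the lower number, and the step therefore records an outcome only.

Going by these compounds, with one step at this position, it remains open whether the lower number is particular to methoxy or would extend to a hydroxyl, an ethoxy or an amine at the same carbon. On these data alone, it is also open whether the same exchange would give a step of similar size and direction on the core of compound 1, and compound 2, with no reported result, adds nothing on fluoro at this position.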